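A few compounds are considered here, and "the series" means these few. Any claim that something is new, unique, unknown or untested is made for them only; others in the source may bear on it.

In a functional assay on KB cells (Homo sapiens) for inhibition (a lower number here means a stronger inhibitor, a higher number a weaker inhibitor), compound 3 `Cc1ccc(Cn2c(Cl)nc3cc(Cl)c(Cl)cc32)cc1` gives > 100000 nM, which is a limit of the assay and not a number. Compound 2 `COc1ccc(Cn2c(Cl)nc3cc(Cl)c(Cl)cc32)cc1` gives > 100000 nM, which is also a limit. Compound 3 therefore has no exact value from which to measure a step. Replacing methyl with tert-butyl on an aromatic carbon, para to a large group, leads to compound 4 `CC(C)(C)c1ccc(Cn2c(Cl)nc3cc(Cl)c(Cl)cc32)cc1` (tert-butyl in place of methyl on an aromatic carbon).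

For the measured compounds named here, the only measured step at this place is a step that the two limits leave unreadable from compound 2 to compound 3, and it gives no size, since both compounds sit at the limit of > 100000 nM in this assay, at which 2 of the 3 values shown sit. The closest guide is compound 1 `CC(C)(C)c1ccc(Cn2c(N)nc3cc(Cl)c(Cl)cc32)cc1`, which also carries tert-butyl but differs elsewhere in the structure. Compound 1 gives 50000 nM, an exact measured value. A measurable value is therefore possible for compound 4, though compound 4 may well stay at the limit. A small move towards stronger inhibition is expected, an at least 1.2-fold lower number from compound 3 to compound 4 (0.09 log units; that floor lies within the scatter). The estimate for compound 4 is 80000 nM, with an expected range from 30000 nM to 150000 nM.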

Compound 4, half-maximal inhibitory concentration: > 100000 nM
Compound 4: a limit, no number; the forecaster's own chance of this, stated with the estimate: 65%; at least 1.2-fold (0.09 log units) between middle value and limit.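

Compound 4 stays at a limit in this assay, so tert-butyl on this aromatic carbon, para to a large group, joins methoxy and methyl in giving no exact value when chloro is on the shared core. The steps among compound 2, compound 3 and compound 4 cannot be read, because all three sit at a limit: the limit of > 100000 nM in this assay, at which 3 of the 4 values shown sit. For the compounds shown here, the one readable step, chloro in place of amino with tert-butyl held fixed, is an at least 2.0-fold higher number from compound 1 to compound 4 (0.30 log units; that floor lies within the scatter), so the measurable value of compound 1 cannot be said to lie beyond the scatter of compound 4.

The compounds shown do not tell whether amino in place of chloro would also give an exact value alongside methyl or methoxy. As far as these compounds go, what a carboxylic acid or a longer chain on this aromatic carbon would give also remains open.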